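Chloro to bromo: what compound 4 may show

This account rests on a few compounds, and the source may have more. Where it says the series, first, only, none or still open, it means among the compounds named here.

In a functional assay on NALM-6 cells (Homo sapiens) for cytotoxicity, read by luminescence and CellTiter-Glo, with a stated time of 3 days (on this read-out higher numbers stand for weaker inhibition and lower numbers for stronger inhibition), compound 1 (`O=C(Nc1cc(C(F)(F)F)cc(C(F)(F)F)c1)c1cc(Cl)c(F)cc1O`) gives 2130 nM as its reading. Two relatives offer context: compound 2 (`O=C(Nc1ccc(OC(F)(F)F)cc1)c1cc(F)ccc1O`) with 1210 nM and compound 3 (`O=C(Nc1ccc(C(F)(F)F)cc1)c1cc(F)ccc1O`) with 2090 nM on the same read-out. All three numbers lie within the usual scatter of one another, so compound 1 stands level with both and the three cannot be ranked.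

Compound 4 (`O=C(Nc1cc(C(F)(F)F)cc(C(F)(F)F)c1)c1cc(Br)c(F)cc1O`) has not been measured yet. Its difference from compound 1 is a single swap: bromo in place of chloro on an aromatic carbon that is, bromo in place of chloro on an aromatic carbon, para to a hydroxy group and ortho to a fluoro group.

Among the compounds with values here, only one measured step is available as a guide, and it is a different swap, trifluoromethyl in place of trifluoromethoxy on an aromatic carbon. That step, a 1.7-fold higher number from compound 2 to compound 3 (0.24 log units; within the scatter) stays small. Within the data shown here, no measured pair shows chloro replaced by bromo, so this is weak evidence. Even so, no shift beyond the scatter is expected in this assay and no direction can be argued from these data. The estimated step is a 1.1-fold lower number from compound 1 to compound 4 (0.03 log units; within the scatter) and it is expected to stay within the scatter. For compound 4 the expected value is 2000 nM with an estimated range from 900 nM to 4500 nM around it.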

Compound 4, half-maximal inhibitory concentration: 950 nM
Compound 4: middle estimate off by 2.1-fold (0.32 log units), on the high side; measured number inside the range.
By their numbers in this assay, from the lowest: compounds 4, 2, 3 and 1 (each within the scatter of the next, the first and the last beyond it).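

In this assay, within the data shown here, bromo in place of chloro gives a 2.2-fold lower number from compound 1 to compound 4 (0.35 log units; beyond the scatter), the first step that clears the usual scatter, although it remains modest. The earlier compounds shown here could not show this, since their readings could not be ranked and none of them carried a change at this spot: an aromatic carbon ortho to a fluoro group and para to a hydroxy group. The result shows that, with the rest of compound 1 held constant, this position is not indifferent to which of these two halogens it carries, even though each is a single heavy atom with no hydrogen-bond donors or acceptors and no net charge, and nothing available here explains the difference.

From the compounds shown here alone, whether iodo, a methyl group or an amine at the same carbon would give a lower or a higher number remains open. Also open, going by these compounds, is whether bromo in place of chloro would give a similar step in a compound with a different group elsewhere on the shared core.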